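Nitro to amino exchange: notes toward compound 4

This account rests on a few compounds, and the source may have more. Where it says the series, first, only, none or still open, it means among the compounds named here.

Compound 1 `COc1ccc(/C=C/c2ccc3ccccc3c2)cc1[N+](=O)[O-]` and compound 2 `COc1ccc(/C=C/c2ccc3ccccc3c2)cc1N` share one core; compound 3 `COc1cc(/C=C/c2ccc(N(C)C)c([N+](=O)[O-])c2)cc(OC)c1OC` and compound 4 `COc1cc(/C=C/c2ccc(N(C)C)c(N)c2)cc(OC)c1OC` share another, and the difference between the two cores is not broken down here. In a functional assay on P388 cells (Mus musculus) for inhibition (a higher number here means a weaker inhibitor, a lower number a stronger inhibitor), compound 1 gives only a limit, > 5000 nM. Compound 2 likewise gives only a limit in this assay, > 5000 nM. The change between them is amino in place of nitro on an aromatic carbon, and the step that the two limits leave unreadable from compound 1 to compound 2 cannot be sized because of the limit of > 5000 nM in this assay, at which 3 of the 3 values shown sit. Compound 3 also sits at a limit in this assay, > 5000 nM. Compound 4 differs from compound 3 by amino in place of nitro on an aromatic carbon, the same kind of change as from compound 1 to compound 2, though here the place is ortho to a dimethylamino group rather than ortho to a methoxy group. With every value shown sitting at the limit of > 5000 nM in this assay, at which 3 of the 3 values shown sit, the measured step carries no size over, and nothing numerical can be read for compound 4 from it. Compound 4 is expected to give 8000 nM in this assay, most likely again reported only as a limit. The step this estimate means is a step that the limit leaves unreadable from compound 3 to compound 4, an expectation resting on the unreadable step that the two limits leave unreadable from compound 1 to compound 2.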

Compound 4, half-maximal inhibitory concentration: 1520 nM
Compound 4: middle estimate off by 5.3-fold (0.72 log units), on the high side, and the stated range ends above it.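

In this assay the exchange of nitro for amino on the core of compound 3 gives an at least 3.2-fold lower number from compound 3 to compound 4 (0.51 log units; beyond the scatter). Compound 3 gives > 5000 nM, which is a limit and not a number, so this step has a minimum size only. The same change on the core of compound 1 cannot be read, and the data therefore neither show nor rule out that the step carries from one core to the other, because the values there sit at the assay limit: the limit of > 5000 nM in this assay, at which 3 of the 4 values shown sit.

Left open is whether the step on the core of compound 3 depends on the amino group being ortho to a dimethylamino group, since the two cores differ in more than one place and no pair here separates those differences. Also open, from the compounds shown here alone, is how a hydroxyl or a methylamino group on the same aromatic carbon would read in this assay, which would show whether the step is particular to amino.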